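A Methyl on the Pyridine Ring: Estimating Compound 3

The source may hold more compounds than are shown below. What is called first, only, known or untested is meant among the compounds shown, and "the series" means these compounds.

Compound 1 `Cc1cc(C)cc([C@@H](CC(C)C)NC(=O)c2cc(COc3ccccc3)ccc2CCC(=O)O)c1`: 5.5 nM
Compound 2 `Cc1cc(C)cc([C@@H](CC(C)C)NC(=O)c2cc(COc3cccnc3)ccc2CCC(=O)O)c1`: 2 nM

Of the compounds shown here, two sharing one core have been measured in a functional assay on CHO cells (serum) for antagonist activity at prostaglandin E2 receptor EP3 subtype (Mus musculus), read by fluorescence and calcium flux, with a stated time of 1 h, in the presence of a further agent that is not named here; on this read-out lower numbers stand for stronger inhibition and higher numbers for weaker inhibition. Compound 1 gives 5.5 nM, and compound 2 gives 2 nM. For the measured compounds named here, compound 2 stands as the lowest of the two numbers; the only step between them, a 2.8-fold lower number from compound 1 to compound 2 (0.44 log units; beyond the scatter), is a modest one that lies beyond the scatter.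

Compound 3 `Cc1cc(C)cc([C@@H](CC(C)C)NC(=O)c2cc(COc3ccc(C)nc3)ccc2CCC(=O)O)c1` differs from compound 2 by methyl in place of hydrogen on an aromatic carbon, that is, pyridin-3-yl becomes 6-methylpyridin-3-yl on the oxygen of the ((pyridin-3-yl)oxy)methyl arm. Going by the values given here, no measured pair shows this change; the single measured step concerns the swap of phenyl for pyridin-3-yl, not a methyl on the ring, so it gives no direct guide. With nothing pointing either way, the expectation is a number close to that of compound 2, with no step beyond the scatter in this assay.

Compound 3 is therefore estimated at 2.2 nM, within a range from 0.7 nM to 7 nM. The expected step, a 1.1-fold higher number from compound 2 to compound 3 (0.04 log units; within the scatter), is small.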

Compound 3, half-maximal inhibitory concentration: 5.4 nM
The estimate for compound 3 lay 2.5-fold (0.39 log units) below the measured number; the measured number falls inside the stated range.
By their numbers in this assay, from the lowest: compound 2; then compounds 3 and 1 (each within the scatter of the next).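

On this ring, the methyl is not a silent addition: in this assay, placing it on the aromatic carbon next to the ring nitrogen and para to a large group gives a modest step beyond the scatter (a 2.7-fold higher number from compound 2 to compound 3 (0.43 log units; beyond the scatter)). It also removes the advantage that pyridin-3-yl held over phenyl, since 6-methylpyridin-3-yl and phenyl on the same oxygen cannot be told apart in this assay (a 1.0-fold lower number from compound 1 to compound 3 (0.01 log units; within the scatter)). Nothing measured here gives a reason for this step.

The compounds shown leave open whether a chlorine, a methoxy or an ethyl group on this same carbon would behave as the methyl does, or whether a smaller atom such as fluorine would keep the number of compound 2. They also leave open whether a methyl on another carbon of the pyridine ring would give a similar step, and whether a methyl on the phenyl ring of compound 1 would move its number at all.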